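The compounds below may be only part of what the source reports. "The series", "measured", "known", "first", "only" and "open" are said of these compounds alone.

Of the compounds shown here, three have been measured in an in vitro functional assay on HEK285-7 cells for antagonist activity at prostaglandin D2 receptor 2 (Homo sapiens), read by BRET and beta-arrestin recruitment; a higher number here means a weaker inhibitor, a lower number a stronger inhibitor. Compound 1 `O=C(O)Cc1sc(C(c2ccccc2)c2ccc(Cl)cc2)nc1-c1ccc(Cl)cc1` gives 75 nM, compound 2 `COc1ccc(C(c2ccccc2)c2nc(-c3ccc(Cl)cc3)c(CC(=O)O)s2)cc1` gives 76 nM, and compound 3 `O=C(O)Cc1sc(C(c2ccc(F)cc2)c2ccc(F)cc2)nc1-c1ccccc1` gives 240 nM. Compound 3 stands highest of the three numbers, with both compound 1 and compound 2 below it beyond the scatter. For the measured compounds named here, the one step between measured compounds that differ in a single place, a 1.0-fold higher number from compound 1 to compound 2 (0.01 log units; within the scatter), lies within the scatter and concerns a substituent on one of the two aryl groups attached to the central carbon.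

Compound 4 `O=C(O)Cc1sc(C(c2ccc(F)cc2)c2ccc(F)cc2)nc1-c1ccoc1` differs from compound 3 in one place: furan-3-yl in place of phenyl on an aromatic carbon. Going by the values given here, no measured step touches this position, so nothing among the three compounds tells how this assay responds to a change on the aromatic carbon next to the ring nitrogen. Among the compounds with values here, the only measured step, from compound 1 to compound 2, concerns a different part of the molecule and is small, and it gives no ground for expecting a large move here. The step from compound 3 to compound 4 is therefore expected to be a 1.3-fold higher number from compound 3 to compound 4 (0.10 log units; within the scatter), with no clear direction beyond the scatter. Compound 4 is estimated at 300 nM, with a range from 110 nM to 900 nM.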

Compound 4, half-maximal inhibitory concentration: 130 nM
Beside the measured number, compound 4's estimate is 2.3-fold (0.36 log units) above it, and the stated range covers the measured number.
By their numbers in this assay, from the lowest: compounds 1, 2, 4 and 3 (each within the scatter of the next, the first and the last beyond it).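

In this assay, for the compounds shown here, furan-3-yl in place of phenyl on the aromatic carbon next to the ring nitrogen gives a 1.8-fold lower number from compound 3 to compound 4 (0.27 log units; within the scatter), the first measured step at this position. It shows that this place can hold a five-membered aromatic ring with a hetero atom instead of a six-membered aromatic ring of carbon only, with no move beyond the scatter, even though furan-3-yl, unlike phenyl, counts a hydrogen-bond acceptor. Phenyl is therefore not needed here to keep the number in this range, at least among compounds that carry the two fluorinated aryl groups shared by compound 3 and compound 4, and no measured information is available to explain the step.

The compounds shown leave open whether furan-2-yl, thiophen-3-yl, a pyridine ring or a saturated ring such as piperidine would also stay within the scatter of compound 3 at this place. They also leave open whether furan-3-yl would give a similar step on the core of compound 1, where a chlorophenyl group stands at this position.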